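This account rests on a few compounds, and the source may have more. Where it says the series, first, only, none or still open, it means among the compounds named here.

Of the compounds shown here, three built on one shared core have been measured in an assay on Cerebral cortex for displacement of a labelled ligand from adenosine receptor A1 (Bos taurus); on this read-out lower numbers stand for stronger inhibition and higher numbers for weaker inhibition. Compound 1 `CCCn1c(=O)[nH]c2nc(C3CCCC3)n(C)c2c1=O` gives 149 nM. Compound 2 `CCCn1c(=O)c2nc(C3CCCC3)[nH]c2n(COCC)c1=O` gives 0.493 nM, and compound 3 `CCCn1c(=O)c2nc(C3CCCC3)[nH]c2n(CCCF)c1=O` gives 0.183 nM, the lowest number among the three and therefore the strongest inhibition seen so far; its gap to compound 1 is very wide and goes well beyond the usual scatter.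

Going by the values given here, only one step between measured compounds changes a single place: a 2.7-fold lower number from compound 2 to compound 3 (0.43 log units; beyond the scatter). That step sits on the same aromatic nitrogen that is altered on the way to compound 4 `CCCn1c(=O)c2nc(C3CCCC3)[nH]c2n(/C=C/CI)c1=O`, where the change is 3-iodoprop-1-en-1-yl in place of 3-fluoropropyl on an aromatic nitrogen. A chain of the same length stays in place, so a move of similar or smaller size is expected, though the iodine and the double bond mean the direction is uncertain. The expected outcome for compound 4 is 0.5 nM, within 0.1 nM to 3 nM, which amounts to an estimated 2.7-fold higher number from compound 3 to compound 4 (0.44 log units; beyond the scatter).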

Compound 4, inhibition constant: 0.237 nM
The estimate for compound 4 lay 2.1-fold (0.32 log units) above the measured number; the measured number falls inside the stated range.
By their numbers in this assay, from the lowest: compounds 3 and 4 (each within the scatter of the next); then compound 2; then compound 1.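

Putting 3-iodoprop-1-en-1-yl in place of 3-fluoropropyl on this aromatic nitrogen gives a 1.3-fold higher number from compound 3 to compound 4 (0.11 log units; within the scatter) in this assay, so this change of halogen and added double bond leaves no difference that can be told from the scatter. Set against ethoxymethyl at the same nitrogen, the iodo chain gives a 2.1-fold lower number from compound 2 to compound 4 (0.32 log units; beyond the scatter), a modest step in the same direction as a 2.7-fold lower number from compound 2 to compound 3 (0.43 log units; beyond the scatter), so compound 2 stands above both of the halogen-bearing compounds. Nothing in hand offers a measured reason for these numbers.

As far as these compounds go, in compound 4 the iodine and the double bond arrive together, so their separate contributions stay open; a saturated 3-iodopropyl chain and a 3-fluoroprop-1-en-1-yl chain would pull them apart. Also open, from the compounds shown here alone, is how the read-out responds at this nitrogen to a longer chain, or to a chain ending in an amine or a carboxylic acid.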